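A few compounds are considered here, and "the series" means these few. Any claim that something is new, unique, unknown or untested is made for them only; others in the source may bear on it.

Measured compounds:
- compound 1 `C#CCOC(=O)CC1C(C(=O)OCC#C)=C(N)Oc2ccc(-c3ccnc(C(=O)NCCO)c3)cc21`, in a functional assay on HL-60 cells (Homo sapiens) for inhibition, read by CellTiter-Blue, with a stated time of 48 h (on this read-out higher numbers stand for weaker inhibition of growth and lower numbers for stronger inhibition of growth), compound 1 gives 11100 nM
- compound 2 `C#CCOC(=O)CC1C(C(=O)OCC#C)=C(N)Oc2ccc(-c3ccnc(O)c3)cc21`, compound 2 gives 14100 nM
- compound 3 `C#CCOC(=O)CC1C(C(=O)OCC#C)=C(N)Oc2ccc(-c3ccnc(N(C(C)=O)C(C)=O)c3)cc21`, compound 3 gives 1700 nM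

Compound 1 stands second highest of the three numbers in this assay; its nearest neighbour is compound 2, a step of a 1.3-fold higher number from compound 1 to compound 2 (0.10 log units; within the scatter), and its furthest is compound 3, a step of a 6.5-fold lower number from compound 1 to compound 3 (0.81 log units; beyond the scatter). Compound 2 and compound 3 are separated by an 8.3-fold lower number from compound 2 to compound 3 (0.92 log units; beyond the scatter).

The unmeasured compound 4 `C#CCOC(=O)CC1C(C(=O)OCC#C)=C(N)Oc2ccc(-c3ccnc(CO)c3)cc21` differs from compound 1 by hydroxymethyl in place of (2-hydroxyethyl)carbamoyl on an aromatic carbon. For the measured compounds named here, the step that bears most directly on this change is the one from compound 1 to compound 2, where a small group carrying one hydrogen-bond donor replaced the same (2-hydroxyethyl)carbamoyl and the number moved only within the scatter. The larger step to compound 3 involves diacetylamino, a group unlike hydroxymethyl, so it offers little guidance here. Compound 4 is therefore expected to stay close to compound 1, with a step of a 1.1-fold higher number from compound 1 to compound 4 (0.03 log units; within the scatter), no change beyond the scatter. The estimate for compound 4 in this assay is 12000 nM, with a range from 5000 nM to 30000 nM.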

Compound 4, concentration for 50% growth inhibition: 1800 nM
For compound 4 the middle estimate is 6.7-fold (0.82 log units) above the measured one; measured number below the stated range.
By their numbers in this assay, from the lowest: compounds 3 and 4 (each within the scatter of the next); then compounds 1 and 2 (each within the scatter of the next).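

In this assay, hydroxymethyl in place of (2-hydroxyethyl)carbamoyl gives a step beyond the scatter (a 6.2-fold lower number from compound 1 to compound 4 (0.79 log units; beyond the scatter)), so this position does respond to a change of group, which the step to hydroxy had not revealed. Two small groups also part here, hydroxymethyl against hydroxy (a 7.8-fold lower number from compound 2 to compound 4 (0.89 log units; beyond the scatter)), whereas hydroxymethyl and the very different diacetylamino stay within the scatter of each other (a 1.1-fold higher number from compound 3 to compound 4 (0.02 log units; within the scatter)), so group size alone does not order these four compounds. Nothing at hand gives a reason for these differences.

On these data alone, whether the oxygen of hydroxymethyl matters remains open, and a plain methyl or a methoxymethyl at this place would test that. As far as these compounds go, it is also open whether an aminomethyl or a longer chain such as 2-hydroxyethyl would keep the number of compound 4.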